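The source may report more compounds than this note shows. Statements on the series, on what has been measured and on what is new or still open speak of the compounds shown alone.

Compound 1 `COc1c(OCCCCN2CCN(C)CC2)cc(O)c2c(=O)cc(-c3ccc(Cl)cc3)oc12` and compound 2 `CCN(CC)CCCOc1c(OCc2ccccc2)cc(O)c2c(=O)cc(-c3ccccc3)oc12` share the same core and were both tested in a functional assay on A549 cells (Homo sapiens) for cytotoxicity, read by MTT assay, with a stated time of 72 h; on this read-out higher numbers stand for weaker inhibition and lower numbers for stronger inhibition. In this assay compound 1 gives 1430 nM. For the measured compounds named here, compound 2 gives 3620 nM, the higher of the two numbers, and the gap to compound 1 lies beyond the scatter; since the two compounds differ in more than one place, their values show only that compound 2 is the weaker inhibitor of the pair. Compound 3 `CCN(CC)CCCCOc1c(OCc2ccccc2)cc(O)c2c(=O)cc(-c3ccccc3)oc12` has not yet been measured. It differs from compound 2 by (diethylamino)methyl in place of diethylamino on a saturated chain carbon, three bonds along the chain from an oxygen on an aromatic ring, a lengthening of the chain that carries the amine. Going by the values given here, no single-change step of this kind has been measured, so its size is unknown; a step of no more than modest size, in either direction, is expected. Compound 3 is therefore expected to give about 3000 nM in this assay, within a range from 1200 nM to 7500 nM, which corresponds to an expected step of a 1.2-fold lower number from compound 2 to compound 3 (0.08 log units; within the scatter).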

Compound 3, half-maximal inhibitory concentration: 3910 nM
Compound 3: the middle estimate sits 1.3-fold (0.12 log units) below what was measured, within the range that was stated.
By their numbers in this assay, from the lowest: compound 1; then compounds 2 and 3 (each within the scatter of the next).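

For the compounds shown here, the step from diethylamino to (diethylamino)methyl, on a saturated chain carbon three bonds along the chain from an oxygen on an aromatic ring, is the first single-change step that can be read in this assay, and it gives a 1.1-fold higher number from compound 2 to compound 3 (0.03 log units; within the scatter). At this position, then, the values for the 3-(diethylamino)propyl and 4-(diethylamino)butyl chains cannot be told apart, so this one lengthening does not separate compound 2 from compound 3. No measurement shown here accounts for this result.

From the compounds shown here alone, whether a shorter 2-(diethylamino)ethyl chain or a still longer chain would also leave the value within the scatter remains open. So does the effect of a primary amine in place of the diethylamino group on either chain.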